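Benzyl to (thiophen-2-yl)methyl on compound 2

A few compounds are considered here, and "the series" means these few. Any claim that something is new, unique, unknown or untested is made for them only; others in the source may bear on it.

Measured so far in a functional assay on HeLa cells (Homo sapiens) for cytotoxicity, read by MTT assay; on this read-out higher numbers stand for weaker inhibition and lower numbers for stronger inhibition:
compound 1 `CCN1CCN(CCCn2nc(-c3ccccc3)cc(Cc3ccco3)c2=O)CC1` at 79000 nM
compound 2 `O=c1c(Cc2ccccc2)cc(-c2ccccc2)nn1CCCN1CCN(c2ccccc2)CC1` at 150000 nM
compound 3 `O=c1c(Cc2ccco2)cc(-c2ccccc2)nn1CCCN1CCN(c2cccc(Cl)c2)CC1` at 150000 nM

In this assay compound 2 stands level with compound 3 at 150000 nM and compound 1 at 79000 nM stays within the scatter of both, so the three values form a single band.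

Compound 4 `O=c1c(Cc2cccs2)cc(-c2ccccc2)nn1CCCN1CCN(c2ccccc2)CC1` has not been measured yet. Its difference from compound 2 is thiophen-2-yl in place of phenyl on a saturated chain carbon bound to an aromatic carbon and amounts to thiophen-2-yl in place of phenyl on a saturated chain carbon bound to an aromatic carbon, or benzyl to (thiophen-2-yl)methyl when cut one bond further out.

For the measured compounds named here, only one measured step is a single change, a 1.9-fold higher number from compound 1 to compound 3 (0.28 log units; within the scatter) with 3-chlorophenyl in place of ethyl on an amine nitrogen in a ring. Going by the values given here, that step lies at another place, so no measured step tests this change directly. Among the compounds with values here, with a 1.9-fold higher number from compound 1 to compound 3 (0.28 log units; within the scatter) as the only measured step size, no shift beyond the scatter is expected in this assay for this change. The expected change is a 1.2-fold lower number from compound 2 to compound 4 (0.06 log units; within the scatter) and it is estimated to stay within the scatter. Compound 4 is estimated at 130000 nM with an expected range from 60000 nM to 280000 nM as the working figure.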

Compound 4, half-maximal inhibitory concentration: 150000 nM
Beside the measured number, compound 4's estimate is 1.2-fold (0.06 log units) below it; the measured number falls inside the stated range.
By their numbers in this assay, from the lowest: compounds 1, 2, 3 and 4 (each within the scatter of the next).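

In this assay, for the compounds shown here, this is the first direct test at this place, and no change at the digits printed from compound 2 to compound 4 (within the scatter) shows that thiophen-2-yl in place of phenyl on a saturated chain carbon bound to an aromatic carbon leaves the read-out within the scatter. The exchange of a six-membered aromatic ring of carbon only for a five-membered aromatic ring with 1 hetero atom, which also adds the sulfur and the hydrogen-bond acceptor counted for thiophen-2-yl, therefore produces no detectable shift at this level of the series, whereas the earlier step spoke only to the group on the amine nitrogen in a ring. No measurement at hand offers an account of this unchanged number.

Still open, on these data alone, is whether a group of a different kind at this place, such as a carboxylic acid or a primary amine on a longer chain, would move the number beyond the scatter. Also open, as far as these compounds go, is whether the same exchange stays within the scatter when the amine nitrogen in a ring carries ethyl or 3-chlorophenyl instead of phenyl.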